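A Deazapurine Nucleoside and the Cost of Losing Its Amine

A few compounds are considered here, and "the series" means these few. Any claim that something is new, unique, unknown or untested is made for them only; others in the source may bear on it.

Measured compounds:
- compound 1, `Nc1nccc2c1ncn2[C@H]1C[C@H](O)[C@@H](CO)O1`: 89%
- compound 2, `OCCNc1nccc2c1ncn2C1O[C@H](CO)[C@@H](O)[C@H]1O`: 6%
- compound 3, `Nc1[nH]ccc2ncnc1-2`: < 5%

All three were tested in a functional assay on EL4 cells (Mus musculus) for inhibition, tested at 100 uM; a lower number here means less inhibition, a higher number more inhibition at the concentration tested (going by the name of the read-out). Compound 1 gives 89%, the highest of the two numbers shown. Its nearest neighbour is compound 2 with 6%, a gap far beyond the usual scatter. Compound 3 gives only < 5%, which is a limit of the assay rather than a number, as recorded in the limit of < 5% in this assay, at which 1 of the 3 values shown sits. Among the compounds with values here, no single-change step between measured compounds is available, so the gap between compound 1 and compound 2 can only be read as what their two values show.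

The unmeasured compound 4, `OC[C@H]1O[C@@H](n2cnc3cnccc32)C[C@@H]1O`, differs from compound 1 in one place: hydrogen in place of amino on an aromatic carbon. The change removes the amino group and leaves the rest of compound 1 untouched. With compound 2 and compound 3 both lying low, a loss in this assay is expected for compound 4, and the step of a number 69 percentage points lower from compound 1 to compound 4 (beyond the scatter) is expected to be large, beyond the scatter. Compound 4 is estimated at 20%, within 5% to 55%.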

Compound 4, a percentage reported as inhibition, at one concentration (the size of the read-out at that concentration, not a potency): < 5%
Compound 4: only a limit was reported; the forecaster's own chance of this, stated with the estimate: 25%; middle value at least 15 percentage points from the limit.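

Within the data shown here, this is the first comparison in which a single group changes: with the rest of compound 1 left untouched, hydrogen in place of amino on the aromatic carbon next to the ring nitrogen gives a number at least 84 percentage points lower from compound 1 to compound 4 (beyond the scatter) in this assay. So in this pair, the inhibition depends on the amino group at this position. Compound 4 gives < 5%, which is a limit and not a number, so the step has only a bound for its size and the full loss cannot be read: the limit of < 5% in this assay, at which 2 of the 4 values shown sit.

The compounds shown leave open whether the unsubstituted amine itself is needed, or whether a methylamino group at this carbon would keep the inhibition. They also leave open what a hydroxyl group or a chlorine atom would do there.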